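Adding one more methyl to compound 3

The source may hold more compounds than are shown below. What is called first, only, known or untested is meant among the compounds shown, and "the series" means these compounds.

In a functional assay on cells (Osteoclast, Mus musculus) for inhibition, with a stated time of 10 days (a higher number here means a weaker inhibitor, a lower number a stronger inhibitor), compound 1 (`O=S(=O)(Nc1cccc(CO)c1)c1ccc(-c2ccc(Br)cc2)cc1`) gives 3000 nM against 3000 nM

Let me give the clean version:

Adding one more methyl to compound 3

In this assay compound 1 (`O=S(=O)(Nc1cccc(CO)c1)c1ccc(-c2ccc(Br)cc2)cc1`) reads 3000 nM while compound 2 (`O=S(=O)(Nc1cccc(CO)c1)c1ccc(-c2ccc(F)cc2F)cc1`) reads 200 nM and compound 3 (`Cc1c(CO)cccc1NS(=O)(=O)c1ccc(-c2ccc(F)cc2F)cc1`) reads 120 nM on the same scale. Compound 3 thus shares the low end with compound 2, within the scatter of it and well apart from compound 1. Compound 4 (`Cc1cc(S(=O)(=O)Nc2cccc(CO)c2C)ccc1-c1ccc(F)cc1F`) differs from compound 3 by one change (methyl in place of hydrogen on an aromatic carbon), a methyl in place of hydrogen on an aromatic carbon, ortho to a 2,4-difluorophenyl group. The same kind of exchange elsewhere gave a small step (a 1.7-fold lower number from compound 2 to compound 3 (0.22 log units; within the scatter)). Changing that aryl group itself gave a large one (a 15-fold lower number from compound 1 to compound 2 (1.18 log units; beyond the scatter)), so some risk remains. The expected step is small, with no clear direction (a 1.3-fold higher number from compound 3 to compound 4 (0.10 log units; within the scatter)). Compound 4 is estimated at 150 nM in a range from 50 nM to 500 nM in this assay as the expected outcome.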

Compound 4, half-maximal inhibitory concentration: 35 nM
For compound 4 the middle estimate is 4.3-fold (0.63 log units) above the measured one; the measured number lies below the stated range.
By their numbers in this assay, from the lowest: compound 4; then compounds 3 and 2 (each within the scatter of the next); then compound 1.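

In this assay a methyl in place of hydrogen ortho to a 2,4-difluorophenyl group gives a 3.4-fold lower number from compound 3 to compound 4 (0.54 log units; beyond the scatter) and so moves the number beyond the scatter. The same exchange elsewhere in the molecule gave only a 1.7-fold lower number from compound 2 to compound 3 (0.22 log units; within the scatter), so the size of the step depends on where the methyl enters in these compounds. Nothing measured here accounts for that difference. On these data alone, it remains open whether an ethyl group, a methoxy group or a chlorine atom at this position would lower the number further. Also open, as far as these compounds go, is whether the methyl gives a similar step alongside the 4-bromophenyl group.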